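Benzyl aryl swap on the weakest hydrazone of the set

The compounds below may be only part of what the source reports. "The series", "measured", "known", "first", "only" and "open" are said of these compounds alone.

Of the compounds shown here, three of the shared core have been measured in a functional assay on HeLa cells (Homo sapiens) for antiproliferative activity, read by MTT assay, with a stated time of 72 h; a higher number here means a weaker inhibitor, a lower number a stronger inhibitor. Among the compounds with values here, compound 1 `Cc1cccc(CSc2cc(Cl)c(C)cc2S(=O)(=O)/N=C(\N)N/N=C/C#Cc2ccccc2)c1` gives 11000 nM and compound 3 `Cc1cc(S(=O)(=O)/N=C(\N)N/N=C/C#Cc2ccccc2)c(SCc2ccccc2Cl)cc1Cl` gives 14000 nM; the single step between them, a 1.3-fold higher number from compound 1 to compound 3 (0.10 log units; within the scatter), stays within the scatter. Within the data shown here, compound 2 `C/C(C#Cc1ccccc1)=N\N/C(N)=N/S(=O)(=O)c1cc(C)c(Cl)cc1SCc1ccc(C)cc1` gives 110000 nM, the highest of the three numbers, beyond the scatter from both compound 3 and compound 1; it differs from compound 1 in more than one place, so no single step is drawn there.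

Compound 4 `C/C(C#Cc1ccccc1)=N\N/C(N)=N/S(=O)(=O)c1cc(C)c(Cl)cc1SCc1cccc(Cl)c1` keeps the core of compound 2 and changes only the benzyl aryl: 3-chlorophenyl in place of 4-methylphenyl on a saturated chain carbon bound to a sulfur. Among the measured compounds shown here, the one measured step of the same kind, a 1.3-fold higher number from compound 1 to compound 3 (0.10 log units; within the scatter), a methyl-for-chloro exchange on that aryl, produced no change beyond the scatter. On that basis the step from compound 2 to compound 4 is expected to be small, a 1.1-fold lower number from compound 2 to compound 4 (0.04 log units; within the scatter), with no clear direction.

Compound 4 is therefore estimated at 100000 nM in this assay, in a range from 40000 nM to 250000 nM.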

Compound 4, half-maximal inhibitory concentration: 21000 nM
Beside the measured number, compound 4's estimate is 4.8-fold (0.68 log units) above it; measured number below the stated range.
By their numbers in this assay, from the lowest: compounds 1, 3 and 4 (each within the scatter of the next); then compound 2.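

In this assay, the aryl on the saturated chain carbon bound to a sulfur turns out not to be a silent place: with 3-chlorophenyl in place of 4-methylphenyl, the change is a 5.2-fold lower number from compound 2 to compound 4 (0.72 log units; beyond the scatter). The earlier exchange at this place, a 1.3-fold higher number from compound 1 to compound 3 (0.10 log units; within the scatter), gave no change beyond the scatter, so the flat result on the core of compound 1 does not carry over to the core of compound 2. No measurement at hand explains the difference between the two steps.

The step to compound 4 alters both the substituent and its location on the aryl, and the two effects cannot be separated here. From the compounds shown here alone, what 3-methylphenyl gives on the core of compound 2 stays open, as does a saturated cyclohexyl group at this place.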